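Adding an Ethyl Group to the Amine of Compound 1

The compounds below may be only part of what the source reports. "The series", "measured", "known", "first", "only" and "open" are said of these compounds alone.

Measured in a functional assay on HCT-8 cells (Homo sapiens) for antiproliferative activity, read by MTT assay, with a stated time of 48 h (a higher number here means a weaker inhibitor, a lower number a stronger inhibitor), so far:
Compound 1 `C=C(c1ccc2c(c1)C=CC(C)(C)O2)c1ccc(OC)cc1NC(=O)CN` – 220 nM
Compound 2 `C=C(c1ccc(OC)cc1NC(=O)CNCC)c1ccc(OC)c2c1OC(C)(C)C=C2` – 1380 nM

Compound 1 holds the lower number at 220 nM in this assay and lies beyond the scatter from compound 2. Compound 3 `C=C(c1ccc2c(c1)C=CC(C)(C)O2)c1ccc(OC)cc1NC(=O)CNCC` differs from compound 1 by ethyl in place of hydrogen on an amine nitrogen as ethyl in place of hydrogen on an amine nitrogen. Within the data shown here, no measured pair shows this change alone. Compound 2 also carries ethylamino and gives 1380 nM as its number, so a moderate rise beyond the scatter is expected in this assay for compound 3. The expected move is a 2.5-fold higher number from compound 1 to compound 3 (0.40 log units; beyond the scatter) on this estimate. Compound 3 is estimated at 550 nM within a range of 200 nM to 1500 nM overall.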

Compound 3, half-maximal inhibitory concentration: 2220 nM
Compound 3: the middle estimate sits 4.0-fold (0.61 log units) below what was measured; the whole stated range lies below it.
By their numbers in this assay, from the lowest: compound 1; then compounds 2 and 3 (each within the scatter of the next).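

In this assay, among these compounds, ethyl in place of hydrogen on the amine nitrogen gives a 10-fold higher number from compound 1 to compound 3 (1.00 log units; beyond the scatter) on an otherwise unchanged core, the first direct reading of this change. In this one pair, the amino group of compound 1 therefore outperforms the ethylamino group of compound 3 at this position. Nothing available accounts for the size of this step. Still open, from the compounds shown here alone, is how a methyl group, a longer chain or a second ethyl group on this nitrogen would read. Going by these compounds, whether the same step holds on another core also remains open.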